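Swapping methylamino for aminomethyl on a shared core

The source may report more compounds than this note shows. Statements on the series, on what has been measured and on what is new or still open speak of the compounds shown alone.

Compound 1 `CNc1nn2c(C)cc(C)nc2c1S(=O)(=O)c1ccccc1`: 0.263 nM; 0.26 nM (2 entries)
Compound 2 `CNc1nn2c(NC)cc(C)nc2c1S(=O)(=O)c1ccccc1`: 0.575 nM
Compound 3 `CNc1nn2c(NCCCN(C)C)cc(C)nc2c1S(=O)(=O)c1ccccc1`: 112 nM; 112 nM (2 entries)

Of the compounds shown here, three share one core and have been tested in a functional assay on HEK293 cells for inhibition of 5-hydroxytryptamine receptor 6 (Homo sapiens), read by cAMP accumulation; on this read-out lower numbers stand for stronger inhibition and higher numbers for weaker inhibition. Compound 1 gives 0.263 nM; 0.26 nM (2 entries), and the repeated entries agree closely (the several entries of compound 1 in this assay, 0.263 nM; 0.26 nM (2 entries)). Going by the values given here, compound 2 gives 0.575 nM, the only number among its entries, the others having come back without a single figure. Compound 3, which carries a longer amine-bearing chain at the same position, gives 112 nM; 112 nM (2 entries), a value far above those of compound 1 and compound 2.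

Compound 4 `CNc1nn2c(CN)cc(C)nc2c1S(=O)(=O)c1ccccc1` has not yet been measured in this assay. It differs from compound 2 in one place: aminomethyl in place of methylamino on an aromatic carbon. The same two heavy atoms remain, only joined in a different order, so a donor and an acceptor stay at that position.

The step from compound 2 to compound 4 is expected to be an 8.7-fold higher number from compound 2 to compound 4 (0.94 log units; beyond the scatter), a loss of potency beyond the usual scatter but well short of the gap seen with compound 3. For compound 4 the estimate in this assay is 5 nM, expected within 0.5 nM to 50 nM.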

Compound 4, inhibition constant: 1.86 nM
The estimate for compound 4 lay 2.7-fold (0.43 log units) above the measured number; the range from low to high includes it.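

In this assay, aminomethyl in place of methylamino gives a 3.2-fold higher number from compound 2 to compound 4 (0.51 log units; beyond the scatter), so this position on the aromatic carbon next to the ring nitrogen registers a change in how the same atoms are joined, although the step is modest and compound 4 still gives 1.86 nM. The groups that leave and enter have the same heavy atoms, the same hydrogen-bond donor and acceptor counts and no net charge, so those counts alone do not set the number at this position. Nothing in the data shown accounts for this step.

The compounds shown leave open how hydroxymethyl, dimethylamino or a longer aminoethyl chain would read on this same carbon. They also leave open whether the same swap would give a step of similar size on a different core.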